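Azido to Benzylsulfanyl on a Shared Nucleoside Core

The source may hold more compounds than are shown below. What is called first, only, known or untested is meant among the compounds shown, and "the series" means these compounds.

Compound 1 `[N-]=[N+]=Nc1nccc2c1ncn2[C@H]1C[C@H](O)[C@@H](CO)O1` gives 4% in a functional assay (Homo sapiens) for inhibition of Nucleic Acid, tested at 100 uM; a higher number here means more inhibition at the concentration tested (going by the name of the read-out), a lower number less inhibition. Compound 2 `OC[C@H]1OC(n2cnc3c(NCc4ccccc4)nccc32)[C@H](O)[C@@H]1O` gives 32% in this assay. Compound 3 `[N-]=[N+]=Nc1[nH]ccc2ncnc1-2` gives 20% in this assay.

Among these three numbers compound 1 stands lowest. Its nearest neighbour is compound 3, whose inhibition lies higher by a margin beyond the usual scatter, and compound 2 lies higher still, also beyond the scatter. Among the measured compounds shown here, no pair of measured compounds differs in only one place, so the measured set gives no single-step comparison to lean on.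

Compound 4 `OC[C@H]1O[C@@H](n2cnc3c(SCc4ccccc4)nccc32)C[C@@H]1O` is the unmeasured member. Compared with compound 1, the difference is benzylsulfanyl in place of azido on an aromatic carbon. In carrying a benzyl group on the same position of the core, though through a nitrogen rather than a sulfur, compound 4 resembles compound 2, and compound 2 reaches 32%, well above compound 1, which suggests that a benzyl-bearing group at this carbon goes with more inhibition than the azido group. On that basis the step is expected to go upward, and beyond the scatter, with a number 21 percentage points higher from compound 1 to compound 4 (beyond the scatter) as the estimated size; compound 4 is expected to reach 25%, in a range from 5% to 45%. Whether sulfur in place of nitrogen alters this cannot be told from the measured compounds.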

Compound 4, a percentage reported as inhibition, at one concentration (the size of the read-out at that concentration, not a potency): 18%
Compound 4: middle estimate off by 7 percentage points, on the high side, and the stated range covers the measured number.
By their numbers in this assay, from the lowest: compound 1; then compounds 4 and 3 (each within the scatter of the next); then compound 2.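

Among the compounds shown here, replacing azido with benzylsulfanyl, on the aromatic carbon next to the ring nitrogen, gives the first comparison in this assay between compounds that differ in one place: a number 14 percentage points higher from compound 1 to compound 4 (beyond the scatter). The earlier compounds shown here could not show this, as none of them formed such a pair. The step shows that on the core of compound 1 this carbon can carry a group of 8 heavy atoms, including a six-membered aromatic ring of carbon only, in place of one of 3 heavy atoms with no loss of inhibition, although the gain is modest and rests on this single pair. Nothing measured here bears on why the number rises.

From the compounds shown here alone, what remains open is whether the rise belongs to the sulfur link, to the benzyl ring or to both; a methylsulfanyl group or a plain amine on the same carbon would begin to separate them. Compound 2 also carries a benzyl group, but through nitrogen, and it differs from compound 4 in more than one place, so the effect of sulfur against nitrogen cannot be read from these compounds.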